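This account rests on a few compounds, and the source may have more. Where it says the series, first, only, none or still open, it means among the compounds named here.

Three compounds share one core and differ only in the group carried on a saturated chain carbon bound to a nitrogen on an aromatic ring. In an ADME assay on Huh-7 cells (Homo sapiens) for cytotoxicity, read by MTT assay, with a stated time of 96 h (on this read-out higher numbers stand for lower toxicity in this test and lower numbers for higher toxicity in this test), compound 1 `COc1cc(NCc2scnc2C)ccc1-c1cnco1` gives 58500 nM, compound 2 `CCc1ccc(CNc2ccc(-c3cnco3)c(OC)c2)s1` gives 39100 nM, and compound 3 `COc1cc(NCc2ccc(C)s2)ccc1-c1cnco1` gives 34400 nM. The three numbers lie close together: a 1.5-fold lower number from compound 1 to compound 2 (0.17 log units; within the scatter), a 1.7-fold lower number from compound 1 to compound 3 (0.23 log units; within the scatter) and a 1.1-fold lower number from compound 2 to compound 3 (0.06 log units; within the scatter). Compound 3 therefore stands alongside the other two, its separation from each within the scatter.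

Compound 4 `COc1cc(NCc2ccc(Br)s2)ccc1-c1cnco1` differs from compound 3 in one place: bromo in place of methyl on an aromatic carbon. Among the measured compounds shown here, no measured step exchanges a methyl for a bromo. The nearest comparison is the removal of a methyl from a saturated chain carbon bound to an aromatic carbon, a 1.1-fold lower number from compound 2 to compound 3 (0.06 log units; within the scatter), which stayed within the scatter, and the exchanges of the whole aromatic group, a 1.5-fold lower number from compound 1 to compound 2 (0.17 log units; within the scatter) and a 1.7-fold lower number from compound 1 to compound 3 (0.23 log units; within the scatter), did likewise. Compound 4 is thus expected to show no step beyond the scatter, a 1.0-fold lower number from compound 3 to compound 4 (0.01 log units; within the scatter). Compound 4 is estimated at 34000 nM, with a range from 15000 nM to 80000 nM.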

Compound 4, half-maximal cytotoxic concentration: 39400 nM
Compound 4: the middle estimate sits 1.2-fold (0.06 log units) below what was measured, and the stated range covers the measured number.
By their numbers in this assay, from the lowest: compounds 3, 2, 4 and 1 (each within the scatter of the next).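

Compound 4 shows that a bromo can stand on an aromatic carbon of the five-membered aromatic ring with 1 sulfur, next to the ring sulfur, in place of an alkyl group without a step beyond the scatter in this assay: the exchange for methyl stays within it (a 1.1-fold higher number from compound 3 to compound 4 (0.06 log units; within the scatter)), and so does the exchange for ethyl (a 1.0-fold higher number from compound 2 to compound 4 (0.00 log units; within the scatter)). The 5-bromothiophen-2-yl group also stays within the scatter of the 4-methyl-1,3-thiazol-5-yl group (a 1.5-fold lower number from compound 1 to compound 4 (0.17 log units; within the scatter)), so methyl, ethyl and bromo at this place all leave the read-out undisturbed. No evidence is at hand that bears on this result.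

Going by these compounds, whether an amine, a carboxylic acid or a longer chain at this place would give a step beyond the scatter stays open. Also open, on these data alone, is whether a bromo on the 4-methyl-1,3-thiazol-5-yl group would behave in the same way.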